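Compound 3 as the defluorinated partner of compound 2

The compounds below may be only part of what the source reports. "The series", "measured", "known", "first", "only" and "open" are said of these compounds alone.

Compound 1 `C[C@@H](Oc1cc2oc(=O)n(CCC(=O)O)c2cc1Cl)c1cccnn1` and compound 2 `C[C@@H](Oc1cc2onc(CCC(=O)O)c2cc1Cl)c1ccc(F)cn1` are the two members of the series measured so far in a physicochemical assay for lipophilicity, read by HPLC, at pH 7.4 (on this read-out lower numbers stand for lower lipophilicity and higher numbers for higher lipophilicity), at this stage. Compound 1 reads 0.83 and compound 2 reads 2.47 in this series, which puts compound 2 at the higher of the two numbers, with the gap beyond the usual scatter. Compound 3 `C[C@@H](Oc1cc2onc(CCC(=O)O)c2cc1Cl)c1ccccn1` differs from compound 2 in one place. The change is hydrogen in place of fluoro on an aromatic carbon and reads 5-fluoropyridin-2-yl to pyridin-2-yl, hydrogen in place of fluoro on an aromatic carbon. Going by the values given here, no measured pair shows this change, so the expectation rests on the structural change alone. A small fall is expected, with a number 0.25 log units lower from compound 2 to compound 3 (within the scatter) estimated to stay within the usual scatter. In this assay the estimate for compound 3 is 2.22 with an expected range of 1.9 to 2.55 for the measurement.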

Compound 3, distribution coefficient: 1.99
Estimate against measurement, compound 3: 0.23 log units above; the measured number falls inside the stated range.
By their numbers in this assay, from the lowest: compound 1; then compound 3; then compound 2.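

In this assay, going by these compounds alone, replacing 5-fluoropyridin-2-yl with pyridin-2-yl gives a number 0.48 log units lower from compound 2 to compound 3 (beyond the scatter), the only step so far between compounds that differ in one place. This shows that the read-out responds to a change of a single heavy atom at this aromatic carbon, two atoms from the ring nitrogen, and that the loss of fluoro alone moves the number beyond the scatter. Compound 1 differs from both in more than one place and adds nothing to this reading. No available measurement accounts for the size of the step.

From the compounds shown here alone, whether a methoxy or a nitrile on this same carbon would raise or lower the number remains open. One step also leaves open whether the same exchange of fluoro for hydrogen would give a similar step on the core of compound 1.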